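The compounds below may be only part of what the source reports. "The series", "measured", "known", "first", "only" and "open" are said of these compounds alone.

Working notes on the series. Compound 1 `CC1(C)CC(NC(=O)Nc2ccccc2)c2cc(Br)ccc2O1` gives 2300 nM in a functional assay (aorta) with Rattus norvegicus as the target; a higher number here means that more compound is needed for the effect, a lower number that less compound is needed. Compound 2 `COc1ccccc1NC(=O)NC1CC(C)(C)Oc2ccc(F)cc21` returns only a limit of this assay, > 10000 nM. Compound 3 `COc1ccccc1NC(=O)NC1CC(C)(C)Oc2ccc(Cl)cc21` likewise returns only a limit, > 10000 nM. Compound 3 thus stands at the edge of what this assay reports, with no number of its own, and the step that the two limits leave unreadable from compound 2 to compound 3 cannot be read because it runs between two values sitting at the limit of > 10000 nM in this assay, at which 2 of the 3 values shown sit. Compound 4 `COc1ccccc1NC(=O)NC1CC(C)(C)Oc2ccc(Br)cc21` differs from compound 3 by bromo in place of chloro on an aromatic carbon. Among the measured compounds shown here, the only measured step touching the same position, a step that the two limits leave unreadable from compound 2 to compound 3, gives no size and no direction; compound 1 also carries bromo but differs from the shared core of the others elsewhere, so its 2300 nM bears only loosely on the question. No readable step therefore points either way, and the change is expected to stay within the scatter or, at best, to bring the value just under the limit. Compound 4 is estimated at 8000 nM, within 3000 nM to 20000 nM. The step of an at least 1.2-fold lower number from compound 3 to compound 4 (0.09 log units; that floor lies within the scatter) is the expected size, with a fair chance that only a limit is reported again.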

Compound 4, half-maximal effective concentration: > 10000 nM
Compound 4 was reported as a limit (the forecaster's own chance of this, stated with the estimate: 60%); middle value at least 1.2-fold (0.09 log units) away from the limit.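

Bromo in place of chloro on this aromatic carbon adds a third halogen at the same limit of this assay, so none of the steps among compound 2, compound 3 and compound 4 can be read, and the halogen change shows no readable effect: the limit of > 10000 nM in this assay, at which 3 of the 4 values shown sit.
Among the compounds shown here, with bromo common to both compounds, the one readable step is an at least 4.3-fold higher number from compound 1 to compound 4 (0.63 log units; beyond the scatter), for methoxy in place of hydrogen on an aromatic carbon. Of the compounds shown, compound 1 alone has a number of its own, and it alone lacks the methoxy.

Going by these compounds, whether fluoro, chloro and bromo differ from one another on the core without methoxy stays open, as only bromo appears there. Also open, on these data alone, is how an amine or a carboxylic acid would read in place of the halogen, or ethoxy in place of the methoxy.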